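Exchanging One Aromatic Ring in a Small Inhibitor Series

The compounds below may be only part of what the source reports. "The series", "measured", "known", "first", "only" and "open" are said of these compounds alone.

Values in a functional assay for inhibition, with Homo sapiens as the target; a higher number here means a weaker inhibitor, a lower number a stronger inhibitor:
- compound 1 `CN(C)c1cccc(Nc2nccc(-c3cccnc3)n2)c1`: 1800 nM
- compound 2 `COc1cccc(Nc2nccc(-c3cccnc3)n2)c1`: 300 nM
- compound 3 `c1cc(Nc2nccc(-c3cccnc3)n2)cc(OCCn2ccnc2)c1`: 100 nM

Compound 1 gives the highest number of the three, so it is the weakest inhibitor here. The nearest measured compound is compound 2, reached by a 6.0-fold lower number from compound 1 to compound 2 (0.78 log units; beyond the scatter), and the furthest is compound 3, reached by an 18-fold lower number from compound 1 to compound 3 (1.26 log units; beyond the scatter). Between those two, a 3.0-fold lower number from compound 2 to compound 3 (0.48 log units; beyond the scatter).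

Compound 4 `Cc1ccc(-c2ccnc(Nc3cccc(N(C)C)c3)n2)s1` is not yet measured. It differs from compound 1 in one place: 5-methylthiophen-2-yl in place of pyridin-3-yl on an aromatic carbon.

None of the three measured steps touches this part of the molecule. Each of them changes the group on the other aromatic ring, where dimethylamino is replaced by methoxy or by 2-(1H-imidazol-1-yl)ethoxy, while the pyridin-3-yl ring stays the same in compounds 1, 2 and 3. Within the data shown here, there is therefore no measured step in this assay that bears on the exchange of pyridin-3-yl for 5-methylthiophen-2-yl, and no direction can be read from the data.

In the absence of a guiding step, compound 4 is expected to stay close to compound 1, with no change at the digits printed from compound 1 to compound 4 (within the scatter), a change not expected to go beyond the scatter. The estimate for compound 4 in this assay is 1800 nM, with a range from 500 nM to 6500 nM.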

Compound 4, half-maximal inhibitory concentration: 5700 nM
Estimate against measurement, compound 4: 3.2-fold (0.50 log units) below, and the stated range covers the measured number.
By their numbers in this assay, from the lowest: compound 3; then compound 2; then compound 1; then compound 4.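

In this assay, the exchange of pyridin-3-yl for 5-methylthiophen-2-yl is the only step shown at this position, on an aromatic carbon next to the ring nitrogen, and it gives a 3.2-fold higher number from compound 1 to compound 4 (0.50 log units; beyond the scatter). The earlier compounds shown here varied only the group on the other aromatic ring, so this result adds that the number also responds to a change at this position, even though this step is modest. The two groups match in heavy atom count, hydrogen-bond donors, hydrogen-bond acceptors and net charge, so those counts do not separate them, and nothing available explains why the number rises.

The compounds shown cannot tell whether the step comes from the five-membered ring, the sulfur or the methyl group, and plain thiophen-2-yl, phenyl and pyridin-4-yl would each help to separate these parts. Going by these compounds, it also remains open whether the same exchange would have a similar effect with methoxy or 2-(1H-imidazol-1-yl)ethoxy on the other aromatic ring in place of dimethylamino.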